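Swapping an Ether Link for a Benzyl Link

The source may hold more compounds than are shown below. What is called first, only, known or untested is meant among the compounds shown, and "the series" means these compounds.

Measured so far:
compound 1, `c1ccc(Oc2ccc3c(NCCCNCc4ccco4)ccnc3c2)cc1`: 317 10^-6 cm/s
compound 2, `COc1cccc(CNCCCNc2ccnc3cc(Oc4ccc(Cl)cc4)ccc23)c1O`: 317 10^-6 cm/s
compound 3, `COc1ccc(F)cc1CNCCCNc1ccnc2cc(CCC(C)C)ccc12`: 23 10^-6 cm/s

In an ADME assay for permeability, using PAMPA, with a stated time of 30 min, at pH 7.4 (a lower number here means that the compound crosses the layer more slowly, a higher number that the compound crosses the layer faster), compound 2 gives 317 10^-6 cm/s, level with compound 1 at the digits shown and far above compound 3, so it sits at the top of the three numbers. Compound 4 is `COc1cccc(CNCCCNc2ccnc3cc(Cc4ccc(F)cc4)ccc23)c1O`, not yet measured. It is made from compound 2 by the change (4-fluorobenzyl in place of 4-chlorophenoxy on an aromatic carbon). Going by these compounds, whether this matters is unknown from these data. Among the measured compounds shown here, compound 3, with an isopentyl chain in that place and a different benzyl group, is the only compound with a low number, so a modest drop is expected, with a step of a 1.6-fold lower number from compound 2 to compound 4 (0.20 log units; within the scatter). Compound 4 is estimated at 200 10^-6 cm/s, between 60 10^-6 cm/s and 400 10^-6 cm/s.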

Compound 4, apparent permeability: 23 10^-6 cm/s
Compound 4: the middle estimate sits 8.7-fold (0.94 log units) above what was measured; the whole stated range lies above it.
By their numbers in this assay, from the lowest: compounds 3 and 4 (each within the scatter of the next); then compounds 1 and 2 (each within the scatter of the next).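

Among the compounds shown here, this is the first pair here that differs in one place only, and it shows that this aromatic carbon of the shared core is not a neutral spot in this assay. Putting 4-fluorobenzyl in place of 4-chlorophenoxy gives a 14-fold lower number from compound 2 to compound 4 (1.14 log units; beyond the scatter) even though both groups have the same count of heavy atoms and one aromatic ring. Nothing measured here explains this large step.

The change replaces the oxygen link and the chlorine together, and the compounds shown do not separate the two. Going by these compounds, a 4-fluorophenoxy or 4-chlorobenzyl group at this position remains open.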